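The source may report more compounds than this note shows. Statements on the series, on what has been measured and on what is new or still open speak of the compounds shown alone.

An oral dose study in the rat compares a small set of amides built on two related cores, read out as a functional assay on the whole organism with Rattus norvegicus as the target, at a dose of 3 mg/kg by the oral route; a higher number here means a stronger effect of the compound at the dose given, a lower number a weaker effect. Compound 1, `COc1cc(C(=O)Nc2nn[nH]n2)nc(-c2ccccc2)c1`, gives 97% in this assay. Compound 2, `CCCOc1cc(C(=O)Nc2nn[nH]n2)nc(-c2ccccc2)c1`, differs from compound 1 only by the change ethyl in place of hydrogen on a saturated chain carbon bound to an oxygen on an aromatic ring and in this assay compound 2 gives 100%, so that the step of a number 3 percentage points higher from compound 1 to compound 2 (within the scatter) is no real movement. Compound 3, `Cc1ccc(-c2cc(C)cc(C(=O)Nc3nn[nH]n3)n2)cc1`, carries a different core; how its core differs from that of compound 1 is not broken down here. In this assay compound 3 gives 100%, level with compound 2 and, like compound 2, within the scatter of compound 1.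

Compound 4, `CCCc1cc(C(=O)Nc2nn[nH]n2)nc(-c2ccc(C)cc2)c1`, is not yet measured. It differs from compound 3 by the change (ethyl in place of hydrogen on a saturated chain carbon bound to an aromatic carbon). Within the data shown here, this is the same kind of change as the one from compound 1 to compound 2, though the place is not identical: there the ethyl enters on a saturated chain carbon bound to an oxygen on an aromatic ring, here on a saturated chain carbon bound to an aromatic carbon. Among the measured compounds shown here, the only measured example of this kind of change, a number 3 percentage points higher from compound 1 to compound 2 (within the scatter), left the read-out essentially where it was. Compound 4 is therefore expected to move by about a number 3 percentage points lower from compound 3 to compound 4 (within the scatter), mainly because compound 3 already gives 100% and little room remains above it. Compound 4 is estimated at 97%, with a likely range from 85% to 100%.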

Compound 4, a percentage reported as inhibition, in the whole organism at one dose (the size of the read-out at that dose, not a potency): 50%
Beside the measured number, compound 4's estimate is 47 percentage points above it, outside the stated range (below it).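

In this assay the new step, a number 50 percentage points lower from compound 3 to compound 4 (beyond the scatter), is large and does not repeat the earlier step, a number 3 percentage points higher from compound 1 to compound 2 (within the scatter), so the ethyl change did not carry over unchanged from one core to the other: the same change on two cores in this assay, a number 3 percentage points higher (within the scatter) from compound 1 to compound 2 and a number 50 percentage points lower (beyond the scatter) from compound 3 to compound 4, 53 percentage points apart, beyond the scatter of two such steps

This shows that, within these four compounds, a change that left the read-out in place on the core of compound 1 cannot be assumed to do the same on the core of compound 3. It does not show a general rule, or why the two steps differ: each core supplies a single pair, and the ethyl enters on a saturated chain carbon bound to an oxygen on an aromatic ring in one pair and on a saturated chain carbon bound to an aromatic carbon in the other, so the core and the place of the change cannot be told apart, and a read-out at one dose is not a potency.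

The compounds shown leave open how the read-out runs at the place changed in compound 4 with an ethyl chain, a longer chain such as butyl, or a chain ending in an amine. They also leave open whether a propyl chain would give a similar read-out on the core of compound 1.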